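This account rests on a few compounds, and the source may have more. Where it says the series, first, only, none or still open, it means among the compounds named here.

Compound 1 `COc1nc(-c2nc3ccccc3n2C)cc(-c2ccc(Cl)cc2)c1C#N`; in a functional assay on aorta (Rattus norvegicus, strain Wister) (on this read-out lower numbers stand for stronger inhibition and higher numbers for weaker inhibition), compound 1 gives 145000 nM.
Compound 2 `COc1nc(-c2nc3ccccc3n2C)cc(-c2ccc(F)cc2)c1C#N`; in this assay compound 2 gives 343000 nM.

Among the measured compounds shown here, compound 2 stands at the higher of these two numbers, the weaker inhibitor; its only neighbour is compound 1, and the step of a 2.4-fold higher number from compound 1 to compound 2 (0.37 log units; beyond the scatter) is modest but beyond the scatter. Compound 3 `COc1nc(-c2nc3ccccc3n2C)cc(-c2ccc(C)cc2)c1C#N` differs from compound 2 by methyl in place of fluoro on an aromatic carbon. For the measured compounds named here, the single measured step bears on this change, as it also exchanged the group at this position and moved the number only modestly. A modest move back toward the number of compound 1 is therefore expected, a 2.3-fold lower number from compound 2 to compound 3 (0.36 log units; beyond the scatter). Compound 3 is estimated at 150000 nM, with a range from 60000 nM to 400000 nM.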

Compound 3, half-maximal inhibitory concentration: 295000 nM
Estimate against measurement, compound 3: 2.0-fold (0.29 log units) below, and the stated range covers the measured number.
By their numbers in this assay, from the lowest: compound 1; then compounds 3 and 2 (each within the scatter of the next).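

In this assay, methyl in place of fluoro gives a 1.2-fold lower number from compound 2 to compound 3 (0.07 log units; within the scatter) and so does not separate these two groups at this para position. Methyl in place of chloro gives a 2.0-fold higher number from compound 1 to compound 3 (0.31 log units; beyond the scatter) and shows that chloro, which also stands apart from fluoro, stands apart from methyl too, though only modestly. Nothing available explains this small preference for chloro.

As far as these compounds go, whether an amine, a carboxylic acid or a longer chain here would move the number much further remains open. So does the effect of changes elsewhere on the shared core.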